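Swapping methyl for chloro on the aryl ring

The compounds below may be only part of what the source reports. "The series", "measured", "known", "first", "only" and "open" are said of these compounds alone.

Compound 1, `CN(C)CCC(NC(=O)C#Cc1ccccc1)c1ccc(Cl)cc1`, gives 398 nM in a functional assay on NIH3T3 cells for agonist activity at Urotensin-2 receptor (Homo sapiens), with a stated time of 5 days; a lower number here means that less compound is needed, a higher number that more compound is needed for the effect.
Compound 2, `CN(C)CCC(NC(=O)/C=C/c1ccc(C(F)(F)F)cc1)c1ccc(Cl)cc1`, gives 129 nM in this assay.
Compound 3, `Cc1ccc(C(CCN(C)C)NC(=O)/C=C/c2ccccc2)cc1`, gives 1550 nM in this assay.

Compound 3 has the highest number of the three, beyond the scatter from compound 1 and further still from compound 2. Compound 4, `CN(C)CCC(NC(=O)/C=C/c1ccccc1)c1ccc(Cl)cc1`, differs from compound 3 by chloro in place of methyl on an aromatic carbon, giving 4-chlorophenyl instead of 4-methylphenyl. Within the data shown here, no measured pair shows this change alone. Since compound 1 and compound 2, both carrying chloro there, give lower numbers than compound 3, compound 4 is expected to show a downward step beyond the scatter in this assay, about a 4.4-fold lower number from compound 3 to compound 4 (0.65 log units; beyond the scatter). Compound 4 is estimated at 350 nM, within 120 nM to 1000 nM.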

Compound 4, half-maximal effective concentration: 427 nM
Estimate against measurement, compound 4: 1.2-fold (0.09 log units) below; the measured number falls inside the stated range.
By their numbers in this assay, from the lowest: compound 2; then compounds 1 and 4 (each within the scatter of the next); then compound 3.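

The change from 4-methylphenyl to 4-chlorophenyl can now be read on its own, and in this assay it gives a 3.6-fold lower number from compound 3 to compound 4 (0.56 log units; beyond the scatter). With chloro kept in place, hydrogen in place of trifluoromethyl gives a 3.3-fold higher number from compound 2 to compound 4 (0.52 log units; beyond the scatter), so a second position also moves the number. 2-Phenylethenyl in place of 2-phenylethynyl gives a 1.1-fold higher number from compound 1 to compound 4 (0.03 log units; within the scatter), which is no real difference.

Among the compounds shown, the aromatic position carries only methyl and chloro, so how fluoro, methoxy or a nitrile would behave there stays open. Nothing available here explains the step from methyl to chloro.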